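Trimming a Long Alkyl Chain on a Shared Core

The source may report more compounds than this note shows. Statements on the series, on what has been measured and on what is new or still open speak of the compounds shown alone.

Three compounds share one core and differ only in the length of a straight alkyl chain. Compound 3 `CCCCCCCCCCCCCCCC1=CC(=O)C=C(OC)C1=O` carries the longest chain, compound 1 `CCCCCCCCCCCCCC1=CC(=O)C=C(OC)C1=O` a shorter one, and compound 2 `CCCCCC1=CC(=O)C=C(OC)C1=O` the shortest. In an assay on isolated protein for inhibition of Polyunsaturated fatty acid 5-lipoxygenase (Homo sapiens), read by ELISA, with a stated time of 10 min (on this read-out lower numbers stand for stronger inhibition and higher numbers for weaker inhibition), compound 3 gives 790 nM, compound 1 gives 1050 nM, and compound 2 gives 1370 nM. All three values sit close together, and the differences between them fall within the usual scatter of repeated measurements, so none of the three can be called apart from the others.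

Among the compounds with values here, the one directly comparable step, a 1.3-fold lower number from compound 1 to compound 3 (0.12 log units; within the scatter), shows that lengthening the chain by two carbons barely moved the number. Compound 4 `CCCCCCCCCCCC1=CC(=O)C=C(OC)C1=O` goes the other way: hydrogen in place of butyl on a saturated chain carbon, ten or more bonds along the chain from a double-bonded ring carbon. The values of compound 2 and compound 1 show that even a much larger shortening of the chain stays within the scatter, so no step beyond the scatter is expected for a 1.3-fold higher number from compound 3 to compound 4 (0.10 log units; within the scatter). Compound 4 is therefore estimated at 1000 nM, with a plausible range from 600 nM to 1700 nM.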

Compound 4, half-maximal inhibitory concentration: 340 nM
For compound 4 the middle estimate is 2.9-fold (0.47 log units) above the measured one, and the stated range ends above it.
By their numbers in this assay, from the lowest: compound 4; then compounds 3, 1 and 2 (each within the scatter of the next).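

Hydrogen in place of butyl on a saturated chain carbon gives a 2.3-fold lower number from compound 3 to compound 4 (0.37 log units; beyond the scatter), so chain length at this position can move the number in this assay beyond the scatter. The comparisons with the two remaining chains point the same way, with a 4.0-fold lower number from compound 2 to compound 4 (0.61 log units; beyond the scatter) and a 3.1-fold lower number from compound 1 to compound 4 (0.49 log units; beyond the scatter), which gives compound 4 the lowest number of the four. Among these compounds, neither "longer is better" nor "shorter is better" holds: compound 4 has a chain intermediate in length between those of compound 2 and compound 1, yet both of those compounds and compound 3 give higher numbers, and no measurement available here explains this.

From the compounds shown here alone, it remains open whether a chain slightly longer or shorter than that of compound 4 would lower the number further, which would show how narrow this favourable range of lengths is. Going by these compounds, it is also open whether the chain would tolerate a carboxylic acid or an amine at its far end, or whether a phenyl ring there would give a similar value.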